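The source may hold more compounds than are shown below. What is called first, only, known or untested is meant among the compounds shown, and "the series" means these compounds.

Measured so far: compound 1 `Cc1cc(F)c(S(C)(=O)=O)cc1C(=O)N=C(N)N` gives 44 nM; compound 2 `Cc1cc(C)c(S(C)(=O)=O)cc1C(=O)N=C(N)N` gives 11 nM; compound 3 `CSc1cc(C)c(C(=O)N=C(N)N)cc1S(C)(=O)=O` gives 6 nM, all in a functional assay for inhibition of sodium/hydrogen exchanger (Oryctolagus cuniculus); on this read-out lower numbers stand for stronger inhibition and higher numbers for weaker inhibition.

Among these three numbers compound 2 stands second highest. Its nearest neighbour is compound 3, with a 1.8-fold lower number from compound 2 to compound 3 (0.26 log units; within the scatter), a difference that lies within the scatter, so no order between compound 2 and compound 3 can be claimed. Compound 1 stands furthest away, with a 4.0-fold lower number from compound 1 to compound 2 (0.60 log units; beyond the scatter), a step that lies beyond the scatter.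

Compound 4 `Cc1cc(Sc2ccc(Cl)cc2)c(S(C)(=O)=O)cc1C(=O)N=C(N)N` has not yet been measured. It differs from compound 2 at one place: (4-chlorophenyl)sulfanyl in place of methyl on an aromatic carbon. Among the compounds with values here, the change at this position that bears most directly on it is the one from compound 2 to compound 3, where a methylsulfanyl group entered in place of methyl and the step stayed within the scatter. The exchange of fluoro for methyl or methylsulfanyl gave a 4.0-fold lower number from compound 1 to compound 2 (0.60 log units; beyond the scatter) and a 7.3-fold lower number from compound 1 to compound 3 (0.87 log units; beyond the scatter), both modest. Nothing measured tells how a (4-chlorophenyl)sulfanyl group behaves here, so no step beyond the scatter is expected in either direction. Compound 4 is therefore estimated at 8 nM, in the range 3 nM to 25 nM, meaning an expected step of a 1.4-fold lower number from compound 2 to compound 4 (0.14 log units; within the scatter).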

Compound 4, half-maximal inhibitory concentration: 19 nM
Compound 4: middle estimate off by 2.4-fold (0.38 log units), on the low side; low and high end bracket the measured number.
By their numbers in this assay, from the lowest: compounds 3, 2 and 4 (each within the scatter of the next, the first and the last beyond it); then compound 1.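

In this assay, this position, ortho to a methylsulfonyl group, accepts a group carrying a whole aromatic ring with no step beyond the scatter against methyl, at a 1.7-fold higher number from compound 2 to compound 4 (0.24 log units; within the scatter). The sulfur substituent does matter, however: 4-chlorophenyl in place of methyl on that sulfur gives a 3.2-fold higher number from compound 3 to compound 4 (0.50 log units; beyond the scatter), while the exchange of fluoro for the (4-chlorophenyl)sulfanyl group still gives a 2.3-fold lower number from compound 1 to compound 4 (0.36 log units; beyond the scatter). No available evidence accounts for these steps.

The compounds shown do not separate the part played by the chlorine from that of the ring, which a plain phenylsulfanyl group would address. They also leave open how this position responds when the aromatic ring is attached through oxygen, as in a 4-chlorophenoxy group, or when an amine stands there.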